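This account rests on a few compounds, and the source may have more. Where it says the series, first, only, none or still open, it means among the compounds named here.

Measured in a functional assay on HeLa cells (Homo sapiens) for antiproliferative activity, read by sulforhodamine B assay, with a stated time of 72 h; on this read-out lower numbers stand for stronger inhibition and higher numbers for weaker inhibition:
- compound 1 (`CN(C)C(=S)N/N=C/c1ccc2ccccc2n1`): 90 nM
- compound 2 (`COc1cccc(NC(=S)N/N=C/c2ccc3ccccc3n2)c1`): 74500 nM
- compound 3 (`S=C(N/N=C/c1ccc2ccccc2n1)Nc1cccc(Cl)c1`): 52500 nM

Compound 3 lies within the scatter of compound 2, and the values of both lie far above that of compound 1. Compound 4 (`S=C(N/N=C/c1ccc2ccccc2n1)Nc1ccccc1`) carries hydrogen in place of chloro on an aromatic carbon, meta to a large group (hydrogen in place of chloro on an aromatic carbon). Going by the values given here, the only measured step at this place, chloro in place of methoxy, stays small (a 1.4-fold lower number from compound 2 to compound 3 (0.15 log units; within the scatter)). No step beyond the scatter is therefore expected in this assay, and the estimated step is correspondingly small (a 1.1-fold lower number from compound 3 to compound 4 (0.02 log units; within the scatter)). The estimate for compound 4 is 50000 nM, with an expected range from 18000 nM to 100000 nM.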

Compound 4, half-maximal inhibitory concentration: 27400 nM
Beside the measured number, compound 4's estimate is 1.8-fold (0.26 log units) above it, and the stated range covers the measured number.
By their numbers in this assay, from the lowest: compound 1; then compounds 4, 3 and 2 (each within the scatter of the next, the first and the last beyond it).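

In this assay, going by these compounds alone, hydrogen in place of chloro stays within the scatter (a 1.9-fold lower number from compound 3 to compound 4 (0.28 log units; within the scatter)), whereas hydrogen in place of methoxy gives the first step at this place beyond it, a modest one (a 2.7-fold lower number from compound 2 to compound 4 (0.43 log units; beyond the scatter)). Both remain small beside anilino in place of dimethylamino on the thiocarbonyl carbon (a 300-fold higher number from compound 1 to compound 4 (2.48 log units; beyond the scatter)). No available evidence bears on the origin of these steps.

Open, from the compounds shown here alone, is whether an amine or a carboxylic acid on this aromatic carbon would shift the number further. Also open, going by these compounds, is whether a longer chain in place of dimethylamino would retain the low number of compound 1.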